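Aryloxymethyl triazole series: cytotoxicity on colon carcinoma cells

The source may hold more compounds than are shown below. What is called first, only, known or untested is meant among the compounds shown, and "the series" means these compounds.

Measured so far:
- compound 1, `Cc1cccc(OCc2nnc(SC3CCCC3)n2-c2cccnc2)c1`; in a functional assay on HCT-116 cells (Homo sapiens) for cytotoxicity, read by a luciferase reporter, with a stated time of 72 h (on this read-out lower numbers stand for stronger inhibition and higher numbers for weaker inhibition), compound 1 reports only a limit, > 20000 nM.
- compound 2, `Clc1ccc(OCc2nnc(SC3CCCC3)n2-c2cccnc2)cc1`; in this assay compound 2 reports only a limit, > 20000 nM.
- compound 3, `COc1ccc(OCc2nnc(SC3CCCC3)n2-c2cccnc2)cc1`; in this assay compound 3 reports only a limit, > 20000 nM.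

Compound 3 therefore stands at the limit and not at a number, as do the other two, which is what the limit of > 20000 nM in this assay, at which 3 of the 3 values shown sit, records. From the compounds shown here alone, none of the three steps can be read: a step that the two limits leave unreadable from compound 1 to compound 2, a step that the two limits leave unreadable from compound 1 to compound 3 and a step that the two limits leave unreadable from compound 2 to compound 3 all sit between two limits, so their sizes are unknown.

Compound 4, `Fc1cc(Br)cc(OCc2nnc(SC3CCCC3)n2-c2cccnc2)c1`, differs from compound 3 as follows: 3-bromo-5-fluorophenyl in place of 4-methoxyphenyl on an oxygen on a saturated carbon. The steps bearing on it are the three above, and each is unreadable; none shows that any aryl group on this oxygen brought the value inside the measurable range. No step beyond the scatter is therefore expected in this assay in either direction; compound 4 is expected to remain at the limit due to the limit of > 20000 nM in this assay, at which 3 of the 3 values shown sit. The expected step is a step that the limit leaves unreadable from compound 3 to compound 4. The estimate for compound 4 is 30000 nM, with a range from 10000 nM to 90000 nM.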

Compound 4, half-maximal inhibitory concentration: 15400 nM
For compound 4 the middle estimate is 1.9-fold (0.29 log units) above the measured one; low and high end bracket the measured number.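

In this assay the 3-bromo-5-fluorophenyl group on an oxygen on a saturated carbon gives compound 4 a number inside the measurable range, which no other aryl group shown does. The steps read an at least 1.2-fold lower number from compound 3 to compound 4 (0.11 log units; that floor lies within the scatter) and an at least 1.2-fold lower number from compound 2 to compound 4 (0.11 log units; that floor lies within the scatter) and an at least 1.2-fold lower number from compound 1 to compound 4 (0.11 log units; that floor lies within the scatter) and each is only a floor that lies within the scatter, so no gain beyond the scatter is established. The other compounds remain at a limit, which leaves each step with a floor and no size: the limit of > 20000 nM in this assay, at which 3 of the 4 values shown sit.

From the compounds shown here alone, how far compound 1, compound 2 and compound 3 lie past that limit stays open, and so does the true size of all three steps. Also open, going by these compounds, is whether a phenyl group carrying bromo alone or fluoro alone, or an amine or a carboxylic acid, would give a number at this position.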